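Swapping the aryl ether for a pyridine ring

The source may hold more compounds than are shown below. What is called first, only, known or untested is meant among the compounds shown, and "the series" means these compounds.

Two compounds share one core and differ only in the ring hung on the ether oxygen. Compound 1 `Cc1cccc(Oc2cc(F)cc(N3Cc4ccccc4S3(=O)=O)c2)c1` carries a 3-methylphenyl there, and in a functional assay on Flp-In T-REx293 cells for antagonist activity at Free fatty acid receptor 1 (Homo sapiens), read by calcium flux (a lower number here means a stronger inhibitor, a higher number a weaker inhibitor), compound 1 gives 25100 nM. Compound 2 `N#Cc1ccc(Oc2cc(F)cc(N3Cc4ccccc4S3(=O)=O)c2)cc1` carries a 4-cyanophenyl instead, and in this assay compound 2 gives 617 nM. Among the measured compounds shown here, the one step measured so far, a 41-fold lower number from compound 1 to compound 2 (1.61 log units; beyond the scatter), shows that this ring governs the read-out: of the two numbers known, compound 2 holds the lower one, and compound 1 is far above it.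

Compound 3 `O=S1(=O)c2ccccc2CN1c1cc(F)cc(Oc2ccncc2)c1` is not yet measured. It changes the same position again: pyridin-4-yl in place of 4-cyanophenyl on an oxygen on an aromatic ring. For the measured compounds named here, only the step from compound 1 to compound 2 bears on this, and it tells that the ring on the oxygen can move the number a long way, but it does not say how a pyridine ring compares with a cyanophenyl. The estimate therefore stays close to compound 2 while allowing a drift toward weaker inhibition, an expected step of a 2.4-fold higher number from compound 2 to compound 3 (0.39 log units; beyond the scatter). Compound 3 is expected to give 1500 nM, with a range from 300 nM to 8000 nM.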

Compound 3, half-maximal inhibitory concentration: > 100000 nM
Compound 3: no number, only a limit; the forecaster's own chance of this, stated with the estimate: 10%; at least 66-fold (1.82 log units) between middle value and limit.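

In this assay compound 3 stands at > 100000 nM, which is a limit of the assay and not a number: the limit of > 100000 nM in this assay, at which 1 of the 3 values shown sits. The change is far from a neutral swap, with an at least 160-fold higher number from compound 2 to compound 3 (2.20 log units; beyond the scatter), so pyridin-4-yl does not stand in for 4-cyanophenyl at this position, even though each group counts as one hydrogen-bond acceptor and neither carries a net charge. The 3-methylphenyl group, which looked poor until now, also compares well with pyridin-4-yl, with an at least 3.9-fold higher number from compound 1 to compound 3 (0.60 log units; beyond the scatter), so of the three rings on the oxygen, pyridin-4-yl sits at the weak end and the earlier range of this position turns out to be wider than the first two compounds showed.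

The three compounds leave open which part of the 4-cyanophenyl group goes with the lower number: the nitrile, or the ring of carbon only that carries it. A plain phenyl ring on the same oxygen, or a phenyl ring bearing a carboxylic acid or a primary amide in place of the nitrile, would begin to separate these two parts.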